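The source may report more compounds than this note shows. Statements on the series, on what has been measured and on what is new or still open speak of the compounds shown alone.

Compound 1 `COc1ccc(/C=C2\C(=O)N(Cc3cn([C@@H]4O[C@H](COC(C)=O)[C@@H](OC(C)=O)[C@H](OC(C)=O)[C@H]4OC(C)=O)nn3)c3ccccc32)cc1OC` gives 23300 nM in a functional assay on A549 cells (Homo sapiens) for cytotoxicity, read by sulforhodamine B assay, with a stated time of 48 h; on this read-out higher numbers stand for weaker inhibition and lower numbers for stronger inhibition. Compound 2 `CC(=O)OC[C@H]1O[C@@H](n2cc(CN3C(=O)/C(=C\C=C\c4ccccc4)c4ccccc43)nn2)[C@H](OC(C)=O)[C@@H](OC(C)=O)[C@@H]1OC(C)=O` gives 58400 nM in this assay, a change of a 2.5-fold higher number from compound 1 to compound 2 (0.40 log units; beyond the scatter). Compound 3 `CC(=O)OC[C@H]1O[C@@H](n2cc(CN3C(=O)/C(=C/C=C/c4ccccc4)c4ccccc43)nn2)[C@H](OC(C)=O)[C@@H](OC(C)=O)[C@@H]1OC(C)=O` reaches only the limit of this assay, > 100000 nM. The step of an at least 1.7-fold higher number from compound 2 to compound 3 (0.23 log units; that floor lies within the scatter) rests on the fact that compounds 2 and 3 differ only in the configuration as drawn and ends at the limit of > 100000 nM in this assay, at which 1 of the 3 values shown sits. Compound 4 `CCC/C=C1/C(=O)N(Cc2cn([C@@H]3O[C@H](COC(C)=O)[C@@H](OC(C)=O)[C@H](OC(C)=O)[C@H]3OC(C)=O)nn2)c2ccccc21` differs from compound 3 by propyl in place of 2-phenylethenyl on a double-bonded chain carbon bound to a double-bonded ring carbon. Of the measured steps only a 2.5-fold higher number from compound 1 to compound 2 (0.40 log units; beyond the scatter) swapped the group on the double-bonded chain carbon bound to a double-bonded ring carbon, and it was modest. Compound 3 offers no number to move from. Compound 4 is therefore expected to sit near the same limit, estimated at 100000 nM with a range of 30000 nM to 300000 nM. The expected step of a number no higher from compound 3 to compound 4 (the limit leaves the size open) is thus none beyond the scatter.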

Compound 4, half-maximal inhibitory concentration: 24100 nM
Compound 4: the middle estimate sits 4.1-fold (0.62 log units) above what was measured; the whole stated range lies above it.
By their numbers in this assay, from the lowest: compounds 1 and 4 (each within the scatter of the next); then compound 2. At a limit, above all of these: compound 3.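

Propyl in place of 2-phenylethenyl gives an at least 4.1-fold lower number from compound 3 to compound 4 (0.61 log units; beyond the scatter), the only step at this position toward a lower number. As far as these compounds go, compound 3 stands at a limit, > 100000 nM, so that step is a floor and its true size stays unknown. Compound 1 gives 23300 nM and compound 4 gives 24100 nM, so a six-membered aromatic ring on this carbon is not needed to reach such a value.

Still open, from the compounds shown here alone, is whether a longer chain such as pentyl, or an amine at the chain end, moves the number further. Also open, going by these compounds, is how the other drawn configuration of the double bond behaves with propyl.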